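Thiophen-2-yl for Cyclopentyl at the Carbonyl Carbon

The source may report more compounds than this note shows. Statements on the series, on what has been measured and on what is new or still open speak of the compounds shown alone.

Compound 1 `O=C(CCc1ccccc1)NC(=S)N1CCc2c(OCCCCCOc3ccc(Cl)cc3)cccc21` gives, as a limit only, > 50000 nM in an ADME assay on Huh-7 cells (Homo sapiens) for cytotoxicity; on this read-out higher numbers stand for lower toxicity in this test and lower numbers for higher toxicity in this test.
Compound 2 `O=C(NC(=S)N1CCc2c(OCCCCCOc3ccc(Cl)cc3)cccc21)C1CCCC1` gives, as a limit only, > 50000 nM in this assay.

Compound 2 stands at a limit rather than at a number in this assay. Compound 1 sits at a limit as well, which is the limit of > 50000 nM in this assay, at which 2 of the 2 values shown sit. Within the data shown here, the single measured step, a step that the two limits leave unreadable from compound 1 to compound 2, is therefore unreadable in size. Compound 3 `O=C(NC(=S)N1CCc2c(OCCCCCOc3ccc(Cl)cc3)cccc21)c1cccs1` differs from compound 2 by thiophen-2-yl in place of cyclopentyl on a carbonyl carbon. No readable measured step bears on this change; the only one measured is unreadable, and both values shown sit at the same limit. Compound 3 is therefore expected to remain at that limit as well, with no step beyond the scatter. The step is estimated as a number no higher from compound 2 to compound 3 (the limit leaves the size open). Compound 3 is estimated at 50000 nM, in a range from 30000 nM to 100000 nM.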

Compound 3, half-maximal cytotoxic concentration: 10700 nM
Beside the measured number, compound 3's estimate is 4.7-fold (0.67 log units) above it; measured number below the stated range.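

In this assay, the group on the carbonyl carbon proves able to move the read-out, which the earlier pair could not show: thiophen-2-yl in place of cyclopentyl gives an at least 4.6-fold lower number from compound 2 to compound 3 (0.66 log units; beyond the scatter), and thiophen-2-yl in place of phenethyl gives an at least 4.6-fold lower number from compound 1 to compound 3 (0.66 log units; beyond the scatter). On this read-out a lower number stands for higher toxicity in this test, while the step from phenethyl to cyclopentyl still cannot be read. Compound 3 is the only compound shown that gives a number rather than a limit, and the other two share a single limit: the limit of > 50000 nM in this assay, at which 2 of the 3 values shown sit.

The compounds shown leave open whether the lower number goes with the aromatic ring or with its sulfur, as phenyl and furan-2-yl on this carbonyl carbon do not stand among them. Also open, from the compounds shown here alone, is how an aminomethyl group or a carboxylic acid on this carbon would read in this assay.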